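Replacing the nitrile on the aryl amide of compound 2

This account rests on a few compounds, and the source may have more. Where it says the series, first, only, none or still open, it means among the compounds named here.

For the measured compounds named here, compound 2 `N#Cc1cc(F)c(NC(=O)C2=NOC3(CCN(c4nc(-c5ccccc5)no4)CC3)C2)cc1F` holds the lowest of the two numbers measured so far in an in vitro functional assay on cells for agonist activity at Glucose-dependent insulinotropic receptor (Homo sapiens), read by AlphaScreen and cAMP accumulation, with a stated time of 45 min; on this read-out lower numbers stand for an effect already at smaller amounts and higher numbers for an effect only at larger amounts of compound. Its nearest neighbour is compound 1 `CC(C)(C)OC(=O)N1CCC2(CC1)CC(C(=O)Nc1cc(F)c(C#N)cc1F)=NO2`, which in this assay gives 93 nM, whereas compound 2 gives 30 nM; the step of a 3.1-fold lower number from compound 1 to compound 2 (0.49 log units; beyond the scatter) accompanies the exchange of the tert-butoxycarbonyl group on the ring amine for 3-phenyl-1,2,4-oxadiazol-5-yl. Compound 3 `C[S+]([O-])c1cc(F)c(NC(=O)C2=NOC3(CCN(c4nc(-c5ccccc5)no4)CC3)C2)cc1F` keeps that oxadiazole and the shared core but alters the aryl amide end: a group of 3 heavy atoms (1 carbon, 1 oxygen, 1 sulfur; no ring) in place of a group of 2 heavy atoms (1 carbon, 1 nitrogen; no ring), on an aromatic carbon. Going by the values given here, no measured step touches this part of the molecule, so the single known step, from compound 1 to compound 2, offers no guide to the direction or size of the change. The step of a 1.5-fold higher number from compound 2 to compound 3 (0.18 log units; within the scatter) is the expected one, with little confidence in its direction. The estimate for compound 3 in this assay is 45 nM, within a range from 12 nM to 180 nM.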

Compound 3, half-maximal effective concentration: 21 nM
Compound 3: the middle estimate sits 2.1-fold (0.33 log units) above what was measured; the range from low to high includes it.
By their numbers in this assay, from the lowest: compounds 3 and 2 (each within the scatter of the next); then compound 1.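

In this assay, for the compounds shown here, the position on the aromatic carbon para to a large group, which no earlier step had touched, accepts a clear exchange of groups: the step is a 1.4-fold lower number from compound 2 to compound 3 (0.15 log units; within the scatter). The cyano group can therefore give way to the larger group of 3 heavy atoms (1 carbon, 1 oxygen, 1 sulfur) with the two compounds remaining indistinguishable on this read-out, so the nitrile itself is not needed to keep the number at this level. Nothing available explains why the two groups match here. On these data alone, it remains open whether this tolerance extends to quite different groups at this position, such as an amine, a carboxylic acid or a longer chain. As far as these compounds go, it is also open whether the same exchange would hold with tert-butoxycarbonyl on the ring amine in place of 3-phenyl-1,2,4-oxadiazol-5-yl.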